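From Propyl to Isopropyl on a Shared Core

The source may report more compounds than this note shows. Statements on the series, on what has been measured and on what is new or still open speak of the compounds shown alone.

Values measured in a functional assay on SW620/5-FU cells (Homo sapiens) for cytotoxicity, read by MTT assay, with a stated time of 48 h, in the presence of a further agent that is not named here; a lower number here means that less compound is needed, a higher number that more compound is needed for the effect:
compound 1 `COc1ccc(-c2cc(NNC(=O)Nc3cc(Cl)nc(Cl)c3)nc3c2cnn3C)cc1`: 18500 nM
compound 2 `Cn1ncc2c(-c3ccccc3)cc(NNC(=O)Nc3cc(Cl)nc(Cl)c3)nc21`: 76900 nM
compound 3 `CCCc1cc(NNC(=O)Nc2cc(Cl)nc(Cl)c2)nc2c1cnn2C`: 38700 nM

The account turns to compound 3. Two measured steps fix its place: a 2.1-fold higher number from compound 1 to compound 3 (0.32 log units; beyond the scatter), and a 2.0-fold lower number from compound 2 to compound 3 (0.30 log units; within the scatter). Compound 4 `CC(C)c1cc(NNC(=O)Nc2cc(Cl)nc(Cl)c2)nc2c1cnn2C` differs from it by a single change, isopropyl in place of propyl on an aromatic carbon, opposite the ring nitrogen: isopropyl in place of propyl on an aromatic carbon. Among the compounds with values here, the two have the same atoms, joined differently, and no measured step tests this exchange directly. Exchanging phenyl for propyl on that carbon gave only a 2.0-fold lower number from compound 2 to compound 3 (0.30 log units; within the scatter), and the largest step among these compounds, a 4.2-fold higher number from compound 1 to compound 2 (0.62 log units; beyond the scatter), was still modest. A step beyond the scatter is therefore not expected here. The expected step is a 1.0-fold lower number from compound 3 to compound 4 (0.01 log units; within the scatter). For compound 4 the estimated value in this assay is 38000 nM, with an expected range from 17000 nM to 85000 nM.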

Compound 4, half-maximal effective concentration: 50100 nM
The estimate for compound 4 lay 1.3-fold (0.12 log units) below the measured number; low and high end bracket the measured number.
By their numbers in this assay, from the lowest: compound 1; then compounds 3, 4 and 2 (each within the scatter of the next).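

In this assay, the exchange on the aromatic carbon opposite the ring nitrogen gives a 1.3-fold higher number from compound 3 to compound 4 (0.11 log units; within the scatter) and so does not tell these two arrangements of the same atoms apart. Against phenyl on that carbon, isopropyl gives a 1.5-fold lower number from compound 2 to compound 4 (0.19 log units; within the scatter) and again cannot be separated, while against 4-methoxyphenyl it gives a 2.7-fold higher number from compound 1 to compound 4 (0.43 log units; beyond the scatter) and the gap is clear, so among the four groups seen here at this place only 4-methoxyphenyl stands apart. Nothing available explains any of these steps.

The compounds shown leave open whether a longer chain such as butyl, a cyclopropyl ring or an amine on this carbon would give a number that stands clear of propyl and isopropyl. They also leave open whether other groups on the phenyl ring, such as ethoxy or hydroxy, would match methoxy.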